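This account rests on a few compounds, and the source may have more. Where it says the series, first, only, none or still open, it means among the compounds named here.

Three compounds were measured in a functional assay on MCF7 cells (Homo sapiens) for antiproliferative activity, read by MTT assay, with a stated time of 48 h; on this read-out higher numbers stand for weaker inhibition and lower numbers for stronger inhibition.

Compound 1 `O=[N+]([O-])c1cccc(-c2nn(-c3ccccc3)cc2C(Nc2nc3ccccc3s2)c2c(O)ccc3ccccc23)c1` gives 43900 nM.
Compound 2 `O=[N+]([O-])c1cccc(-c2nn(-c3ccccc3)cc2C(Nc2nc3ccc(Cl)cc3s2)c2c(O)ccc3ccccc23)c1` gives 19700 nM.
Compound 3 `Oc1ccc2ccccc2c1C(Nc1nc2ccc(Cl)cc2s1)c1cn(-c2ccccc2)nc1-c1cccc(Cl)c1` gives 17500 nM.

Compound 2 and compound 3 are built on the same core, and the difference between them is chloro in place of nitro on an aromatic carbon. This change gives a 1.1-fold lower number from compound 2 to compound 3 (0.05 log units; within the scatter), so the two values cannot be told apart. Compound 1 differs from compound 2 by hydrogen in place of chloro on an aromatic carbon, and that step gives a 2.2-fold higher number from compound 2 to compound 1 (0.35 log units; beyond the scatter).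

Compound 4 `Oc1ccc2ccccc2c1C(Nc1nc2ccc(Cl)cc2s1)c1cn(-c2ccccc2)nc1-c1ccccc1` has not yet been measured in this assay. It differs from compound 3 by hydrogen in place of chloro on an aromatic carbon. Within the data shown here, this is the same kind of change as the one from compound 2 to compound 1, but not the same: there the chloro sat on a ring that is part of a fused or bridged system of two rings, meta to a fused ring and para to a fused ring, whereas here it sits on a six-membered aromatic ring of carbon only, meta to a large group. Among the measured compounds shown here, only one earlier step of this kind is known, and it was modest and beyond the scatter. A step of similar direction is expected here, estimated at a 1.6-fold higher number from compound 3 to compound 4 (0.20 log units; within the scatter), resting on the earlier 2.2-fold higher number from compound 2 to compound 1 (0.35 log units; beyond the scatter) while allowing for the different place, which makes the size uncertain. For compound 4 the estimate in this assay is 28000 nM, with a likely range from 12000 nM to 70000 nM.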

Compound 4, half-maximal inhibitory concentration: 36300 nM
The estimate for compound 4 lay 1.3-fold (0.11 log units) below the measured number; the range from low to high includes it.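

In this assay, the change from 3-chlorophenyl to phenyl gives a 2.1-fold higher number from compound 3 to compound 4 (0.32 log units; beyond the scatter), a modest weakening of inhibition. Hydrogen in place of chloro on an aromatic carbon thus weakened inhibition on both cores, by steps that cannot be told apart, even though the chloro sits at a different place in each pair: the same change on two cores in this assay, a 2.2-fold higher number (0.35 log units; beyond the scatter) from compound 2 to compound 1 and a 2.1-fold higher number (0.32 log units; beyond the scatter) from compound 3 to compound 4, 1.1-fold (0.03 log units) apart, within the scatter of two such steps. This shows that, for these two pairs and in this one assay, the size of the step carried over from one core to the other, but two pairs do not establish a rule for the series, and they do not show whether the step would hold on another core or why the chloro matters at either place.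

On the six-membered aromatic ring of carbon only, hydrogen in place of nitro gives a 1.8-fold higher number from compound 2 to compound 4 (0.27 log units; within the scatter), which stays within the scatter, so the compounds shown do not separate hydrogen from nitro at that place, although chloro stands apart from hydrogen there. They leave open how an amine, a methoxy group or a carboxylic acid would read at that place, and whether the chloro step would keep its size with any of these groups elsewhere on the core.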